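A few compounds are considered here, and "the series" means these few. Any claim that something is new, unique, unknown or untested is made for them only; others in the source may bear on it.

Measured so far in a functional assay on HeLa cells (Homo sapiens) for antiproliferative activity, read by MTT assay, with a stated time of 48 h; on this read-out lower numbers stand for stronger inhibition and higher numbers for weaker inhibition:
compound 1 `Cc1ccc2nc(NC(c3cn(-c4ccccc4)nc3-c3cccc(Cl)c3)c3c(O)ccc4ccccc34)sc2c1` — 9430 nM
compound 2 `O=[N+]([O-])c1cccc(-c2nn(-c3ccccc3)cc2C(Nc2nc3ccc(Cl)cc3s2)c2c(O)ccc3ccccc23)c1` — 15500 nM

In this assay compound 2 gives the larger of the two numbers, but compound 1 lies within the usual scatter of it, so these two compounds are not separated by the data at hand. Compound 3 `Oc1ccc2ccccc2c1C(Nc1nc2ccc(Cl)cc2s1)c1cn(-c2ccccc2)nc1-c1cccc(Cl)c1` differs from compound 2 in one place: chloro in place of nitro on an aromatic carbon. For the measured compounds named here, no pair of measured compounds shows this exchange on its own, so there is no measured step to lean on. Going by the values given here, the two numbers known for this pair of compounds sit close together, and a single exchange of one substituent on the phenyl ring is expected to leave the number near that of compound 2. The step of a 1.4-fold lower number from compound 2 to compound 3 (0.15 log units; within the scatter) is expected to be small, no larger than the scatter, in either direction. For compound 3 the estimate in this assay is 11000 nM, within a range from 4500 nM to 27000 nM.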

Compound 3, half-maximal inhibitory concentration: 18300 nM
The estimate for compound 3 lay 1.7-fold (0.22 log units) below the measured number, and the stated range covers the measured number.
By their numbers in this assay, from the lowest: compounds 1, 2 and 3 (each within the scatter of the next).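

In this assay, the exchange of 3-nitrophenyl to 3-chlorophenyl gives a 1.2-fold higher number from compound 2 to compound 3 (0.07 log units; within the scatter), so nitro and chloro are not told apart at this place, meta to a large group. A second exchange, from methyl to chloro at a different place in the molecule, gives a 1.9-fold higher number from compound 1 to compound 3 (0.29 log units; within the scatter), so these two groups are not told apart there either. No independent measurement bears on these results.

The compounds shown leave open whether an amine or a carboxylic acid in place of the chloro on the phenyl ring would give a number beyond the scatter. The same question stands for a methoxy group or a longer chain at the place where methyl and chloro were exchanged.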